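A few compounds are considered here, and "the series" means these few. Any claim that something is new, unique, unknown or untested is made for them only; others in the source may bear on it.

In an ADME assay on HCT-116 cells (Homo sapiens) for antiproliferative activity (on this read-out lower numbers stand for stronger inhibition and higher numbers for weaker inhibition), compound 1 `COc1ccc(C(C)=O)cc1COc1ccc(Cl)cc1` gives 39000 nM. Compound 3 `COc1ccc(C(N)=O)cc1/C=C/c1ccccc1` gives 36000 nM, which lies within the usual scatter of the value for compound 1. Compound 2 `COc1ccc(C(=O)O)cc1COc1ccc(Cl)c(C)c1` reads > 50000 nM, and this is a limit of the assay, not a number. Compound 4 `COc1ccc(C(N)=O)cc1/C=C/c1ccc(Br)cc1` has not yet been measured and departs from compound 3 in one place: bromo in place of hydrogen on an aromatic carbon, para to a large group. Going by the values given here, no measured pair differs in one place, so the expectation rests on compound 3 at 36000 nM and on this change alone. A modest step to a lower number in this assay is expected, estimated as a 2.4-fold lower number from compound 3 to compound 4 (0.38 log units; beyond the scatter). For compound 4 the estimated value is 15000 nM, with an expected range of 5000 nM to 45000 nM.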

Compound 4, half-maximal inhibitory concentration: 22000 nM
Compound 4: the middle estimate sits 1.5-fold (0.17 log units) below what was measured; low and high end bracket the measured number.
By their numbers in this assay, from the lowest: compounds 4, 3 and 1 (each within the scatter of the next). At a limit, above all of these: compound 2.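

In this assay, bromo in place of hydrogen on an aromatic carbon, para to a large group, gives the first step read at this position (a 1.6-fold lower number from compound 3 to compound 4 (0.21 log units; within the scatter)). Going by these compounds alone, this position therefore carries a bromine atom with no step beyond the scatter, which the earlier compounds, differing from one another in more than one place, could not show. Nothing in the data shown bears on the cause of this step.

On these data alone, whether an amine or a nitrile at this position would move the number beyond the scatter remains open. So does whether bromo gives a similar step on the core of compound 1.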